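Microsomal stability: hydroxy-dioxothianyl amide replacing oxabicyclic acid

This account rests on a few compounds, and the source may have more. Where it says the series, first, only, none or still open, it means among the compounds named here.

Measured in an ADME assay on microsomes from liver (Mus musculus) for metabolic stability, with a stated time of 10 min; a higher number here means that more of the compound is left, a lower number that less of the compound is left:
- compound 1 `C[C@]1(C(=O)N2CC[C@](c3ccc(C(F)(C(F)(F)F)C(F)(F)F)cc3)(S(=O)(=O)c3ccc(F)cc3)C2)CC[C@@H](C(=O)O)CC1`: 100%
- compound 2 `O=C(O)C12CCC(C(=O)N3CC[C@](c4ccc(C(F)(C(F)(F)F)C(F)(F)F)cc4)(S(=O)(=O)c4ccc(F)cc4)C3)(CC1)OC2`: 94%
- compound 3 `O=C1NC(=O)C2(CCC(C(=O)N3CC[C@](c4ccc(C(F)(C(F)(F)F)C(F)(F)F)cc4)(S(=O)(=O)c4ccc(F)cc4)C3)CC2)N1`: 81%; 82% (2 entries)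

Compound 2 holds the lower of the two single numbers; the step of a number 6 percentage points lower from compound 1 to compound 2 (within the scatter) separates it from compound 1. Compound 3 stands apart with two entries, (the several entries of compound 3 in this assay, 81%; 82% (2 entries)), which agree closely.

Compound 4 `O=C(N1CC[C@](c2ccc(C(F)(C(F)(F)F)C(F)(F)F)cc2)(S(=O)(=O)c2ccc(F)cc2)C1)C1(O)CCS(=O)(=O)CC1` is unmeasured. Compared with compound 2: a group of 9 heavy atoms (5 carbon, 3 oxygen, 1 sulfur; one six-membered non-aromatic ring with 1 hetero atom) in place of a group of 11 heavy atoms (8 carbon, 3 oxygen; one six-membered non-aromatic ring of carbon only, one six-membered non-aromatic ring with 1 hetero atom), on a carbonyl carbon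

Going by the values given here, only one measured step touches this position, a number 6 percentage points lower from compound 1 to compound 2 (within the scatter), and it stayed within the scatter. Among the compounds with values here, the new change is larger in kind, yet no measured pair shows a shift at this position, so no step beyond the scatter is expected in this assay. The step from compound 2 to compound 4 is estimated at a number 6 percentage points lower from compound 2 to compound 4 (within the scatter). For compound 4 the expected value is 88%, range 70% to 100%.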

Compound 4, percent of the compound remaining: 90%
Compound 4: middle estimate off by 2 percentage points, on the low side; the measured number falls inside the stated range.
By their numbers in this assay, from the lowest: compounds 4, 2 and 1 (each within the scatter of the next).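

With 4-hydroxy-1,1-dioxothian-4-yl on the carbonyl carbon, the position accepts a group without a carboxylic acid in this assay: the step is a number 4 percentage points lower from compound 2 to compound 4 (within the scatter), and the wider comparison is a number 10 percentage points lower from compound 1 to compound 4 (within the scatter). Before this, the single-place step at this position involved only groups carrying a carboxylic acid. Nothing measured here gives a cause for these numbers.

Whether the hydroxy group on the ring matters stays open, as no compound shown separates it from the rest of the group. An amine in its place would test this directly.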